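Working notes: from compound 3 to compound 4

The source may hold more compounds than are shown below. What is called first, only, known or untested is meant among the compounds shown, and "the series" means these compounds.

Compound 1 `CS(=O)(=O)c1ccc(-c2oc3ccccc3c(=S)c2-c2ccc(F)cc2)cc1` gives < 5% in an assay on isolated protein for inhibition of prostaglandin G/H synthase 1 (Mus musculus), tested at 10 ug/mL (on this read-out higher numbers stand for more inhibition at the one concentration tested (going by the name of the read-out) and lower numbers for less inhibition), which is a limit of the assay and not a number.
Compound 2 `CS(=O)(=O)c1ccc(-c2oc3ccccc3c(=O)c2-c2cccc(Cl)c2)cc1` gives < 5% in this assay, again a limit.
Compound 3 `CS(=O)(=O)c1ccc(-c2oc3ccccc3c(=O)c2-c2ccc(Cl)cc2)cc1` gives < 5% in this assay, also a limit.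

Compound 3 therefore stands at a limit only, and the two further values shown are limits as well: all three sit at the limit of < 5% in this assay, at which 3 of the 3 values shown sit. Among the measured compounds shown here, the one step between measured neighbours, a step that the two limits leave unreadable from compound 2 to compound 3, cannot be read because both ends are limits, so no measured step gives a readable size to lean on.

Compound 4 `CS(=O)(=O)c1ccc(-c2oc3ccccc3c(=O)c2-c2cc(Cl)cc(Cl)c2)cc1` differs from compound 3 by 3,5-dichlorophenyl in place of 4-chlorophenyl on an aromatic carbon. For the measured compounds named here, with every measured value at the same limit and the only step unreadable, no step in this assay beyond the scatter is expected from this change. For compound 4 the estimate is 3%, with a range from 0% to 10%, most likely reported as a limit again. The step this estimate means, a step that the limit leaves unreadable from compound 3 to compound 4, is expected to be none beyond the scatter.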

Compound 4, a percentage reported as inhibition, at one concentration (the size of the read-out at that concentration, not a potency): < 5%
Compound 4: only a limit was reported; the forecaster's own chance of this, stated with the estimate: 85%; the middle value does not contradict the limit.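

No new step can be read from compound 2 or compound 3 to compound 4 in this assay, since both ends of each step are limits: the limit of < 5% in this assay, at which 4 of the 4 values shown sit.
The compounds shown leave open whether any change on the shared core gives inhibition readable as a number in this assay.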